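This account rests on a few compounds, and the source may have more. Where it says the series, first, only, none or still open, it means among the compounds named here.

Values in an assay on SW1353 cells (Homo sapiens) for inhibition, read by a luciferase reporter, with stated times of 30 min and 8 h; a higher number here means a weaker inhibitor, a lower number a stronger inhibitor:

compound 1 `O=c1sc2ccccc2n1CCCCN1CCN(CCCCn2c(=O)sc3ccccc32)CC1` — 2280 nM
compound 2 `O=c1oc2ccccc2n1CCCCCN1CCN(CCn2c(=O)oc3ccccc32)CC1` — 4780 nM
compound 3 `O=c1oc2ccccc2n1CCCCCCN1CCN(CCn2c(=O)oc3ccccc32)CC1` — 3070 nM

These three compounds share a central ring with two side chains, each ending in a fused two-ring group. Compound 1 and compound 3 give numbers within the scatter of each other, so nothing separates them; compound 2 gives a number that lies beyond the scatter away from compound 1, on the weaker side.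

Compound 4 `O=c1sc2ccccc2n1CCCCN1CCN(CCCn2c(=O)sc3ccccc32)CC1` has not yet been measured. It differs from compound 1 in one place: a group of 10 heavy atoms (7 carbon, 1 nitrogen, 1 oxygen, 1 sulfur; one five-membered aromatic ring with 2 hetero atoms, one six-membered aromatic ring of carbon only) in place of a group of 11 heavy atoms (8 carbon, 1 nitrogen, 1 oxygen, 1 sulfur; one five-membered aromatic ring with 2 hetero atoms, one six-membered aromatic ring of carbon only), on a saturated chain carbon, three bonds along the chain from an amine nitrogen in a ring. Within the data shown here, the one measured step that speaks to this kind of change, a lengthening of one chain by a single carbon, is a 1.6-fold lower number from compound 2 to compound 3 (0.19 log units; within the scatter), and that step stayed within the scatter. Among the measured compounds shown here, because a 1.6-fold lower number from compound 2 to compound 3 (0.19 log units; within the scatter) shows no clear movement and is the only comparison of this kind, the shortening of one chain in compound 4 is expected to bring about no step beyond the scatter in this assay. Compound 4 is therefore estimated at 2500 nM, with a range from 1200 nM to 5500 nM, which is expected to mean a 1.1-fold higher number from compound 1 to compound 4 (0.04 log units; within the scatter).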

Compound 4, half-maximal inhibitory concentration: 1710 nM
Estimate against measurement, compound 4: 1.5-fold (0.16 log units) above; measured number inside the range.
By their numbers in this assay, from the lowest: compounds 4, 1, 3 and 2 (each within the scatter of the next, the first and the last beyond it).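

In this assay, the step to the shorter chain, a 1.3-fold lower number from compound 1 to compound 4 (0.12 log units; within the scatter), stays within the scatter, so the group of 10 heavy atoms and the group of 11 heavy atoms cannot be told apart at this place, on a saturated chain carbon, three bonds along the chain from an amine nitrogen in a ring. This adds a second reading to a 1.6-fold lower number from compound 2 to compound 3 (0.19 log units; within the scatter): a change of one carbon also leaves the number within the scatter when the end group holds sulfur and oxygen, not two oxygens, and neither listed step goes against this. No measurement bears on why the chain length matters so little here.

The compounds shown leave open whether a much longer chain, or an amine or a hydroxyl group on this chain, would move the number beyond the scatter. They also do not show a pair that differs only in sulfur against oxygen in the end group, so that swap cannot be judged from them.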